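Shortening the ether chain on the shared core

This account rests on a few compounds, and the source may have more. Where it says the series, first, only, none or still open, it means among the compounds named here.

In a functional assay on HCT-116 cells (Homo sapiens) for cytotoxicity, read by MTT assay, with a stated time of 48 h (a higher number here means a weaker inhibitor, a lower number a stronger inhibitor), compound 2 `C=CCOc1ccc2c(NCCCN(C)C)ccnc2c1` gives 2100 nM. Compound 1 `CCCCCCOc1ccc2c(Cl)ccnc2c1` gives 2440 nM and compound 3 `CC(C)COc1ccc2c(Cl)ccnc2c1` gives 2490 nM; both numbers lie within the usual scatter of the number for compound 2, so the three stand together. Compound 4 `CCOc1ccc2c(NCCCN(C)C)ccnc2c1` differs from compound 2 in one place: methyl in place of vinyl on a saturated chain carbon bound to an oxygen on an aromatic ring. Within the data shown here, the only measured step at that same place is the one between compound 1 and compound 3, a 1.0-fold higher number from compound 1 to compound 3 (0.01 log units; within the scatter), which did not move beyond the scatter. Compound 4 is therefore expected to stay close to compound 2, with a step of a 1.0-fold higher number from compound 2 to compound 4 (0.02 log units; within the scatter) that is not expected to exceed the scatter. Compound 4 is estimated at 2200 nM, within a range from 1000 nM to 4800 nM.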

Compound 4, half-maximal inhibitory concentration: 3380 nM
Estimate against measurement, compound 4: 1.5-fold (0.19 log units) below; the range from low to high includes it.
By their numbers in this assay, from the lowest: compounds 2, 1, 3 and 4 (each within the scatter of the next).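

In this assay, replacing allyl with ethyl on the ether gives a 1.6-fold higher number from compound 2 to compound 4 (0.21 log units; within the scatter), so the vinyl double bond can be exchanged for a methyl end in these compounds without a change beyond the scatter. The earlier step at this place, a 1.0-fold higher number from compound 1 to compound 3 (0.01 log units; within the scatter), came from compounds with a different group on the shared core, and the ether position now shows no step beyond the scatter in either pair. Nothing available bears on why these steps have this size. On these data alone, whether a benzyl group or a longer chain ending in an amine on the oxygen would stay within the scatter remains open.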